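Changing One End Group on a Growth Inhibitor

The compounds below may be only part of what the source reports. "The series", "measured", "known", "first", "only" and "open" are said of these compounds alone.

Three related compounds have been measured so far in a functional assay on HOP-62 cells (Homo sapiens) for inhibition, read by sulforhodamine B assay; a lower number here means a stronger inhibitor of growth, a higher number a weaker inhibitor of growth. Compound 3 (`CN(C)c1ccc(-c2ccc(-c3ccc(-c4nc5c(O)cccc5[nH]4)cc3)cc2)cc1`) gives 8250 nM. That value lies within the usual scatter of compound 1 (`COc1ccc(-c2ccc(-c3ccc(-c4nc5ccccc5[nH]4)cc3)cc2)cc1OC`), which gives 4200 nM, but it is a clearly higher number than that of compound 2 (`Oc1cccc2[nH]c(-c3ccc(-c4ccc(-c5ccc(C(F)(F)F)cc5)cc4)cc3)nc12`), which gives 3200 nM.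

The next compound, compound 4 (`COc1ccc(-c2ccc(-c3ccc(-c4nc5c(O)cccc5[nH]4)cc3)cc2)cc1OC`), keeps the core of compound 3 and changes a single end group. It has 3,4-dimethoxyphenyl in place of 4-(dimethylamino)phenyl on an aromatic carbon.

Among the measured compounds shown here, only one measured step involves this end of the molecule on the same core: a 2.6-fold higher number from compound 2 to compound 3 (0.41 log units; beyond the scatter). There, dimethylamino replaced trifluoromethyl, and the effect was modest. A second, rougher guide is compound 1, which carries the same 3,4-dimethoxyphenyl group on a core that is not identical and gives 4200 nM. Neither observation points to a large change, so a small move towards a lower number is expected, probably within the scatter. The estimated size is a 1.7-fold lower number from compound 3 to compound 4 (0.22 log units; within the scatter). For compound 4 the expected value in this assay is 5000 nM, with an estimated range from 2500 nM to 10000 nM.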

Compound 4, concentration for 50% growth inhibition: 2210 nM
For compound 4 the middle estimate is 2.3-fold (0.35 log units) above the measured one; measured number outside the range, below it.
By their numbers in this assay, from the lowest: compounds 4, 2, 1 and 3 (each within the scatter of the next, the first and the last beyond it).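

On the core shared by compounds 2, 3 and 4, the choice of end group can shift the result in this assay: replacing 4-(dimethylamino)phenyl with 3,4-dimethoxyphenyl gives a 3.7-fold lower number from compound 3 to compound 4 (0.57 log units; beyond the scatter) and so moves the number beyond the scatter. Replacing 4-(trifluoromethyl)phenyl with 3,4-dimethoxyphenyl gives a 1.4-fold lower number from compound 2 to compound 4 (0.16 log units; within the scatter) and stays within the scatter, so on this core compound 3 alone stands apart, with a number clearly higher than those of the other two. Among the compounds shown here, the new compound also gives the first direct reading of hydroxy in place of hydrogen on an aromatic carbon of the core, and that change gives a 1.9-fold lower number from compound 1 to compound 4 (0.28 log units; within the scatter), which is also within the scatter, so adding this hydroxy group has no clear effect when the end group is 3,4-dimethoxyphenyl.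

From the compounds shown here alone, it remains open whether a phenyl end group carrying a single methoxy group, a carboxylic acid or a morpholine ring would stay level with compound 4 or move towards compound 3. No measurement shown here explains why these end groups differ.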